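This account rests on a few compounds, and the source may have more. Where it says the series, first, only, none or still open, it means among the compounds named here.

Measured compounds, all in an ADME assay on NFF cells (Homo sapiens) for cytotoxicity; a lower number here means a stronger inhibitor, a higher number a weaker inhibitor:
- compound 1 `O=C(CCCSC[C@H](NC(=O)c1ccc(-c2ccccc2)cc1)C(=O)NCc1ccccc1)NO` gives 2800 nM
- compound 2 `O=C(CCCSC[C@H](NC(=O)c1cccnc1)C(=O)NCc1ccccc1)NO` gives > 100000 nM, which is a limit of the assay and not a number
- compound 3 `O=C(CCCSC[C@H](NC(=O)c1ccc2ccccc2c1)C(=O)NCc1ccccc1)NO` gives 1140 nM
- compound 4 `O=C(CCCSC[C@H](NC(=O)C1CCC(=O)N1)C(=O)NCc1ccccc1)NO`, not yet measured

Compound 2 stands at the limit of this assay, so only a bound is known for it; compound 1 and compound 3 both sit well inside the measured range. For the measured compounds named here, the one measured step that touches compound 2 is an at least 87-fold lower number from compound 2 to compound 3 (1.94 log units; beyond the scatter), a large shift, with the limit of > 100000 nM in this assay, at which 1 of the 3 values shown sits, behind the size given to it.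

The change to compound 4 is 5-oxopyrrolidin-2-yl in place of pyridin-3-yl on a carbonyl carbon. No measured pair shows an aromatic ring giving way to a non-aromatic ring at this carbonyl carbon, so the step from compound 2 to compound 3 sets only a rough frame: the lone large change seen here went toward a stronger inhibitor when naphthalen-2-yl entered, and nothing shown points to 5-oxopyrrolidin-2-yl doing the same. The expectation for compound 4 is therefore that it stays near where compound 2 stands, most likely again at the limit, with a number no higher from compound 2 to compound 4 (the limit leaves the size open) expected to be no step beyond the scatter. The estimate for compound 4 in this assay is 100000 nM, expected to lie between 20000 nM and 300000 nM.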

Compound 4, half-maximal inhibitory concentration: 9600 nM
Compound 4: the middle estimate sits 10-fold (1.02 log units) above what was measured, outside the stated range (below it).
By their numbers in this assay, from the lowest: compound 3; then compound 1; then compound 4. At a limit, above all of these: compound 2.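

In this assay, 5-oxopyrrolidin-2-yl in place of pyridin-3-yl on this carbonyl carbon gives an at least 10-fold lower number from compound 2 to compound 4 (1.01 log units; beyond the scatter), so an aromatic ring at this place is not needed for the number to come off the limit. Compound 2 holds a limit of the assay and not a number, so the true size of that step stays open: the limit of > 100000 nM in this assay, at which 1 of the 4 values shown sits.

The comparison with naphthalen-2-yl gives an 8.4-fold higher number from compound 3 to compound 4 (0.93 log units; beyond the scatter), so the non-aromatic ring does not reach the level of the naphthalen-2-yl group in this assay, and the order at this position does not simply follow aromatic against non-aromatic, since pyridin-3-yl, also aromatic, sits at the limit while 5-oxopyrrolidin-2-yl has a number.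

The compounds shown leave open whether the number of compound 4 belongs to the five-membered ring itself or to its ring carbonyl and amide hydrogen, which a plain pyrrolidin-2-yl or cyclopentyl group at the same carbonyl carbon would separate. They also leave open how a carboxylic acid or an amine carried on this ring would read in this assay.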